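The source may hold more compounds than are shown below. What is called first, only, known or untested is meant among the compounds shown, and "the series" means these compounds.

In a functional assay on DLD-1 cells (Homo sapiens) for cytotoxicity, with a stated time of 48 h (on this read-out higher numbers stand for weaker inhibition and lower numbers for stronger inhibition), compound 1 `C[S+]([O-])/C=C/c1cc(=O)c2ccccc2o1` gives 8000 nM and compound 2 `CC(C)C(=O)Oc1ccc2oc(/C=C/[S+](C)[O-])cc(=O)c2c1` gives 9100 nM as its reading, so the two stand level within the scatter of repeated measurements. Compound 3 `C[S+]([O-])/C=C/c1cc(=O)c2cc(Br)ccc2o1` is still unmeasured and differs from compound 2 at one place: bromo in place of (isopropylcarbonyl)oxy on an aromatic carbon with bromo in place of (isopropylcarbonyl)oxy on an aromatic carbon. Among the measured compounds shown here, the one measured step that bears on this is a 1.1-fold higher number from compound 1 to compound 2 (0.06 log units; within the scatter) and it lies within the scatter. For the measured compounds named here, no bromo compound has been measured, so no shift beyond the scatter is expected in this assay for now. The expected change is a 1.3-fold lower number from compound 2 to compound 3 (0.11 log units; within the scatter) and so stays inside that scatter. Compound 3 is estimated at 7000 nM with a likely range from 2800 nM to 15000 nM on this read-out.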

Compound 3, half-maximal inhibitory concentration: 4500 nM
Compound 3: the middle estimate sits 1.6-fold (0.19 log units) above what was measured; low and high end bracket the measured number.
By their numbers in this assay, from the lowest: compounds 3, 1 and 2 (each within the scatter of the next, the first and the last beyond it).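

In this assay this aromatic carbon shows its first step beyond the scatter: bromo in place of (isopropylcarbonyl)oxy brings a 2.0-fold lower number from compound 2 to compound 3 (0.31 log units; beyond the scatter) and that step is modest. Bromo in place of hydrogen brings a 1.8-fold lower number from compound 1 to compound 3 (0.25 log units; within the scatter) and stays within the scatter, so bromo cannot be told apart from hydrogen here. No evidence is available to explain either step. Going by these compounds, whether chloro, an amine or a carboxylic acid on this carbon would move the number further stays open. So does whether bromo on another carbon of the ring would give the same reading.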